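The source may report more compounds than this note shows. Statements on the series, on what has been measured and on what is new or still open speak of the compounds shown alone.

Measured compounds:
- compound 1 `O=C(O)COc1ccc(Cl)cc1C#Cc1ccncc1` — 601 nM
- compound 2 `CCCc1ccncc1C#Cc1cc(Cl)ccc1OCC(=O)O` — 4.3 nM
- compound 3 `CS(=O)(=O)c1ccc(C#Cc2cc(Cl)ccc2OCC(=O)O)cc1` — 86 nM

All three were run in an assay on CHO cells for displacement of a labelled ligand from prostaglandin D2 receptor 2 (Homo sapiens), read by scintillation counting; a lower number here means a stronger inhibitor, a higher number a weaker inhibitor. Compound 1 gives the highest number of the three, 601 nM, and both gaps from it lie beyond the scatter: compound 3 at 86 nM is the nearer, compound 2 at 4.3 nM the further. The three share the chloro-substituted aryloxyacetic acid core and the triple bond; what differs is the group on the far triple-bonded carbon, and the spread of the three values shows that changes there move the number a great deal.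

Compound 4 `O=C(O)COc1ccc(Cl)cc1C#Cc1ccccc1Cl` is not yet measured. It differs from compound 1 in one place: 2-chlorophenyl in place of pyridin-4-yl on a triple-bonded carbon. Among the compounds with values here, no directly comparable step is on record, so the expectation rests on the spread above. Compounds 2 and 3 both show that replacing the plain pyridin-4-yl of compound 1 can bring the number down sharply, and compound 4 is expected to move the same way, by a step of a 6.0-fold lower number from compound 1 to compound 4 (0.78 log units; beyond the scatter) in this assay, which is expected to lie beyond the scatter. The estimate for compound 4 is 100 nM, with a likely range from 20 nM to 500 nM.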

Compound 4, inhibition constant: 28 nM
Estimate against measurement, compound 4: 3.6-fold (0.55 log units) above; measured number inside the range.
By their numbers in this assay, from the lowest: compound 2; then compound 4; then compound 3; then compound 1.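

In this assay, the step on this triple-bonded carbon, a 21-fold lower number from compound 1 to compound 4 (1.33 log units; beyond the scatter), is large, so this position responds strongly to 2-chlorophenyl in place of pyridin-4-yl. Compound 4 at 28 nM also shows that a low number at this position does not depend on a ring nitrogen, since the entering group is an aromatic ring of carbon only, with no hydrogen-bond acceptor. No measurement here bears on why the number falls with this change.

The step combines loss of the ring nitrogen with gain of chlorine, and a plain phenyl group would be needed to separate the two. On these data alone, it also remains open whether chlorine itself matters, or whether a methyl or methoxy group in its place on the phenyl ring would give a similar number.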